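The source may hold more compounds than are shown below. What is called first, only, known or untested is meant among the compounds shown, and "the series" means these compounds.

In a functional assay on KB cells (Homo sapiens) for cytotoxicity, read by resazurin assay, with a stated time of 3 days (on this read-out higher numbers stand for weaker inhibition and lower numbers for stronger inhibition), three compounds have been measured:

Compound 1 `CC(C)(CNC(=O)c1ccc2ccccc2c1)CC1=C(O)C(=O)c2ccccc2C1=O`: 9000 nM
Compound 2 `CC(C)(CNC(=O)c1ccc2ccccc2c1O)CC1=C(O)C(=O)c2ccccc2C1=O`: 26900 nM
Compound 3 `COc1c(C(=O)NCC(C)(C)CC2=C(O)C(=O)c3ccccc3C2=O)ccc2ccccc12`: 66900 nM

Compound 2 stands second highest of these three numbers: a 3.0-fold higher number from compound 1 to compound 2 (0.48 log units; beyond the scatter), and a 2.5-fold higher number from compound 2 to compound 3 (0.40 log units; beyond the scatter).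

Compound 4 `COc1cc(C(=O)NCC(C)(C)CC2=C(O)C(=O)c3ccccc3C2=O)c(O)c2ccccc12` differs from compound 2 by methoxy in place of hydrogen on an aromatic carbon. The step that bears most on this is a 7.4-fold higher number from compound 1 to compound 3 (0.87 log units; beyond the scatter), which is also a methoxy in place of hydrogen on an aromatic carbon, though added to a compound without the hydroxy of compound 2. In the same direction, a 2.5-fold higher number from compound 2 to compound 3 (0.40 log units; beyond the scatter). A modest rise in the number is therefore expected for compound 4 in this assay, that is a 2.4-fold higher number from compound 2 to compound 4 (0.38 log units; beyond the scatter). Compound 4 is estimated at 65000 nM, within a range of 22000 nM to 200000 nM.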

Compound 4, half-maximal inhibitory concentration: 8620 nM
Beside the measured number, compound 4's estimate is 7.5-fold (0.88 log units) above it; measured number below the stated range.
By their numbers in this assay, from the lowest: compounds 4 and 1 (each within the scatter of the next); then compound 2; then compound 3.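

Adding a methoxy group to an aromatic carbon does not always weaken inhibition. Placed para to a hydroxy group, it strengthens inhibition, with a 3.1-fold lower number from compound 2 to compound 4 (0.49 log units; beyond the scatter). The direction of this change therefore depends on the compound that receives it: the same change on two cores in this assay, a 7.4-fold higher number (0.87 log units; beyond the scatter) from compound 1 to compound 3 and a 3.1-fold lower number (0.49 log units; beyond the scatter) from compound 2 to compound 4, 23-fold (1.37 log units) apart, beyond the scatter of two such steps

On these data alone, whether the stronger inhibition requires the hydroxy group remains open. It is also unclear whether an ethoxy group or an amine on the same carbon would shift the number in the same direction.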